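Adding a Methoxy to a Polymethoxylated Compound

The source may hold more compounds than are shown below. What is called first, only, known or untested is meant among the compounds shown, and "the series" means these compounds.

Measured compounds:
compound 1 `COc1ccc(-c2cc(=O)c3c(OC)c(OC)c(OC)c(OC)c3o2)c(OC)c1`: 15 ug/mL
compound 2 `O=c1cc(-c2cccc([N+](=O)[O-])c2)oc2ccccc12`: 2 ug/mL

In a functional assay on KB cells (Homo sapiens) for cytotoxicity (a higher number here means that more compound is needed for the effect, a lower number that less compound is needed), compound 1 gives 15 ug/mL, the highest of the two numbers recorded; compound 2 gives 2 ug/mL, and the gap between them lies beyond the scatter. Compound 3 `COc1cc(OC)c(-c2cc(=O)c3c(OC)c(OC)c(OC)c(OC)c3o2)cc1OC` differs from compound 1 by one change: methoxy in place of hydrogen on an aromatic carbon. Going by the values given here, no measured pair shows the effect of such a change, so the step is expected to be small, perhaps a slightly higher number, or none beyond the scatter, as a 1.2-fold higher number from compound 1 to compound 3 (0.08 log units; within the scatter). For compound 3 the value expected in this assay is 18 ug/mL, within 6 ug/mL to 50 ug/mL.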

Compound 3, concentration for half-maximal effect: 13 ug/mL
The estimate for compound 3 lay 1.4-fold (0.14 log units) above the measured number; the range from low to high includes it.
By their numbers in this assay, from the lowest: compound 2; then compounds 3 and 1 (each within the scatter of the next).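

In this assay, methoxy in place of hydrogen on an aromatic carbon, ortho to a methoxy group and para to a methoxy group, gives a 1.2-fold lower number from compound 1 to compound 3 (0.06 log units; within the scatter), so at this place the compounds carry the added group without a change beyond the scatter. This is the only pair shown for this change, and nothing measured here bears on the result.

On these data alone, whether a hydroxyl, an amine or a carboxylic acid on this same aromatic carbon would also stay within the scatter remains open. So does the effect of a methoxy placed elsewhere on that ring.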